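Replacing the indolyl group with 4-acetylphenyl in compound 3

This account rests on a few compounds, and the source may have more. Where it says the series, first, only, none or still open, it means among the compounds named here.

Values measured in a functional assay on ECa-109 cells for inhibition, with ECa-109 cell line (Homo sapiens) as the target, read by MTT assay, with a stated time of 48 h; on this read-out higher numbers stand for weaker inhibition and lower numbers for stronger inhibition
compound 1 `CCOC(=O)c1ccc(Nc2nnc(Cl)c(Nc3cc(OC)c(OC)c(OC)c3)n2)cc1` gives 46600 nM
compound 2 `COc1cc(Nc2nc(Nc3ccc4c(ccn4C)c3)nnc2Cl)cc(OC)c1OC` gives 42100 nM

For the measured compounds named here, only these two compounds have numbers so far. In this assay compound 2 at 42100 nM lies within the usual scatter of compound 1 at 46600 nM on this read-out, so neither can be ranked over the other. Going by the values given here, no pair of measured compounds differs in just one place, so the data do not yet show what a single exchange does here.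

Compound 3 `COc1cc(Nc2nc(Nc3ccc(C(C)=O)cc3)nnc2Cl)cc(OC)c1OC` comes from compound 2 by one exchange 4-acetylphenyl in place of 1-methyl-1H-indol-5-yl on a nitrogen on an aromatic ring in which 4-acetylphenyl stands in place of 1-methyl-1H-indol-5-yl on a nitrogen on an aromatic ring. Among the compounds with values here, the only guide is how closely the two known numbers agree, and that is thin evidence. In this assay no shift beyond the scatter is expected, in either direction. The estimated step is a 1.1-fold lower number from compound 2 to compound 3 (0.04 log units; within the scatter) and so stays within the scatter. For compound 3 the expected value is 38000 nM with an estimated range from 14000 nM to 90000 nM for the coming measurement.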

Compound 3, half-maximal inhibitory concentration: 36300 nM
For compound 3 the middle estimate is 1.0-fold (0.02 log units) above the measured one, within the range that was stated.
By their numbers in this assay, from the lowest: compounds 3, 2 and 1 (each within the scatter of the next).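

In this assay, for the compounds shown here, the exchange of 1-methyl-1H-indol-5-yl for 4-acetylphenyl on a nitrogen on an aromatic ring gives a 1.2-fold lower number from compound 2 to compound 3 (0.06 log units; within the scatter) and is the first single exchange that can be read at this position. Although a group with a five-membered and a six-membered aromatic ring leaves and a group with only a six-membered aromatic ring enters, the two numbers cannot be told apart. The second exchange, methyl in place of ethoxy on a carbonyl carbon, gives a 1.3-fold lower number from compound 1 to compound 3 (0.11 log units; within the scatter) and likewise stays within the scatter, so these three aryl groups on that nitrogen cannot be ranked, and no measurement here bears on why the exchanges leave the read-out within the scatter.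

The compounds shown leave open whether a primary amine or a carboxylic acid on the phenyl ring in place of the acetyl group would move the number beyond the scatter. They also leave open what an exchange elsewhere would do, such as an amine in place of the chlorine on the shared core, since that part stays the same in all three compounds.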